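The compounds below may be only part of what the source reports. "The series", "measured", "known", "first", "only" and "open" are said of these compounds alone.

Measured so far in a functional assay on RAW264.7 cells (Mus musculus) for inhibition, read by ELISA, with stated times of 1 h and 18 h, tested at 20 uM; a higher number here means a weaker effect of the compound at the concentration tested, a lower number a stronger effect:

Compound 1, `C=C1CC[C@H]2C(C)(C)CCC[C@]2(C)[C@H]1C/C=C1\CC(O)OC1=O`, gives 59.4%.
Compound 2, `C=C1CC[C@H]2C(C)(C)CCC[C@]2(C)[C@H]1C/C=C1\CC(OC)OC1=O`, gives 59.9%.

These two numbers sit close together: the step of a number 0.5 percentage points higher from compound 1 to compound 2 (within the scatter) is too small to count as a real difference, so compound 2 stands beside compound 1 rather than apart from it, with neither compound clearly stronger or weaker in this assay.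

Compound 3, `C=C1CC[C@H]2C(C)(C)CCC[C@]2(C)[C@H]1C/C=C1\CC(OCC)OC1=O`, has not yet been measured in this assay. It differs from compound 2 by methyl in place of hydrogen on a saturated chain carbon bound to an oxygen on a saturated carbon. Going by the values given here, the only step available that bears on this change is the one already made at the same spot, a number 0.5 percentage points higher from compound 1 to compound 2 (within the scatter), where adding a methyl to the oxygen left the number where it was. Taking that as the guide, lengthening the group on that oxygen by one more carbon is expected to change the number in this assay by about a number 0.1 percentage points higher from compound 2 to compound 3 (within the scatter), that is, by nothing beyond the scatter in either direction.

Compound 3 is therefore estimated to give 60% in this assay, with a range of 50% to 70%.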

Compound 3, a percentage reported as activity, at one concentration (the size of the read-out at that concentration, not a potency): 80.9%
Estimate against measurement, compound 3: 20.9 percentage points below, and the stated range ends below it.
By their numbers in this assay, from the lowest: compounds 1 and 2 (each within the scatter of the next); then compound 3.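

In this assay, the group on this oxygen turns out to matter: the step of a number 21 percentage points higher from compound 2 to compound 3 (beyond the scatter) shows that going from methoxy to ethoxy weakens the effect at the concentration tested, even though the earlier swap of hydrogen for methyl on the same oxygen moved the number by nothing beyond the scatter. Counted from the hydrogen of compound 1, putting ethyl in its place gives a number 21.5 percentage points higher from compound 1 to compound 3 (beyond the scatter) and so sets compound 3 apart from both of the other compounds, which means that the read-out does not shift evenly as this group grows: methyl leaves it in place, while ethyl raises it. Nothing measured here accounts for this jump.

Still open, from the compounds shown here alone, is whether a longer chain such as propyl or butyl on this oxygen would raise the number further, hold it steady or bring it back down. Going by these compounds, it is equally open whether a branched isopropyl group, a benzyl group or an acetyl group on the same oxygen would behave like methyl or like ethyl.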